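A Second Acid Enters the Adamantane Trioxolane Series

This account rests on a few compounds, and the source may have more. Where it says the series, first, only, none or still open, it means among the compounds named here.

Compound 2 `O=C(O)c1cccc([C@H]2CC[C@]3(CC2)OOC2(O3)C3CC4CC(C3)CC2C4)c1` is one of two measured members of this set; the other is compound 1 `O=C(O)CNC(=O)COc1ccc([C@H]2CC[C@]3(CC2)OOC2(O3)C3CC4CC(C3)CC2C4)cc1`. In a physicochemical assay for lipophilicity, read by HPLC, at pH 7.4 (a lower number here means a more polar compound, a higher number a more lipophilic compound), compound 2 gives 3, and compound 1 gives 3, so the two stand level within the scatter. Compound 3 `O=C(O)COc1ccc([C@H]2CC[C@]3(CC2)OOC2(O3)C3CC4CC(C3)CC2C4)cc1C(=O)O` differs from compound 2 by carboxymethoxy in place of hydrogen on an aromatic carbon. Among the compounds with values here, with no measured step of this kind to lean on, a downward move beyond the scatter is expected, a number 1.40 log units lower from compound 2 to compound 3 (beyond the scatter), because compound 2 sits at 3. Compound 3 is therefore estimated at 1.6, within 0.7 to 2.5.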

Compound 3, distribution coefficient: 1.9
Compound 3: the middle estimate sits 0.30 log units below what was measured; measured number inside the range.
By their numbers in this assay, from the lowest: compound 3; then compounds 1 and 2 (each within the scatter of the next).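

In this assay, within the data shown here, the position ortho to a carboxy group and para to a large group proves responsive: carboxymethoxy in place of hydrogen there gives a number 1.10 log units lower from compound 2 to compound 3 (beyond the scatter) and is the only measured step in the set. A single change at this aromatic carbon thus moves the read-out beyond the scatter. Nothing measured here accounts for the size of this step.

The compounds shown leave open whether a plain methoxy group or an amine at this position would move the number as far. They also leave open whether carboxymethoxy gives a step of this size without the neighbouring carboxy group.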